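Replacing oxan-4-yl with benzyl on an amide chain

The source may hold more compounds than are shown below. What is called first, only, known or untested is meant among the compounds shown, and "the series" means these compounds.

Compound 1 `CCCCC(=O)Nc1ccc(N2CCN(c3ccc(OC[C@@H]4CO[C@@](Cn5cncn5)(c5ccc(Cl)cc5Cl)O4)cc3)CC2)cc1` gives in a toxicity assay on L02 cells (Homo sapiens) for inhibition, read by MTT assay, with a stated time of 48 h; a lower number here means a stronger inhibitor, a higher number a weaker inhibitor > 50000 nM, which is a limit of the assay rather than a number. Compound 2 `O=C(CC1CCOCC1)Nc1ccc(N2CCN(c3ccc(OC[C@@H]4CO[C@@](Cn5cncn5)(c5ccc(Cl)cc5Cl)O4)cc3)CC2)cc1` gives in this assay > 50000 nM, again only a limit.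

Compound 2 therefore sits at the limit of > 50000 nM in this assay, at which 2 of the 2 values shown sit. Going by the values given here, the single measured step, a step that the two limits leave unreadable from compound 1 to compound 2, cannot be sized. Compound 3 `O=C(CCc1ccccc1)Nc1ccc(N2CCN(c3ccc(OC[C@@H]4CO[C@@](Cn5cncn5)(c5ccc(Cl)cc5Cl)O4)cc3)CC2)cc1` carries benzyl in place of oxan-4-yl on a saturated chain carbon bound to a carbonyl carbon. Among the compounds with values here, no measured step speaks to this change, so no shift beyond the scatter is expected in this assay. Compound 3 is estimated at 80000 nM, with a range from 30000 nM to 300000 nM, most likely again reported only as a limit. The estimated step that the limit leaves unreadable from compound 2 to compound 3 is expected to be none beyond the scatter.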

Compound 3, half-maximal inhibitory concentration: > 50000 nM
Compound 3: no number, only a limit (the forecaster's own chance of this, stated with the estimate: 85%); the middle value is on the limit's open side.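

Going by these compounds alone, compound 1, compound 2 and compound 3 each give only a limit, so no step between them can be read: the limit of > 50000 nM in this assay, at which 3 of the 3 values shown sit. The compounds shown leave open at what concentration any of the three would inhibit in this assay.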